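Replacing the Terminal Aryl Urea with a Simple Benzamide

This account rests on a few compounds, and the source may have more. Where it says the series, first, only, none or still open, it means among the compounds named here.

Three compounds share one core and differ only in the group on the amide-type nitrogen. Compound 1 `COc1cc(-c2nn(-c3cccc(NC(=O)Nc4ccc(Cl)c(Cl)c4)c3)cc2-c2ccncc2)ccc1Cl` gives 12900 nM in a functional assay on MDA-MB-231 cells (Homo sapiens) for inhibition, read by sulforhodamine B assay, with a stated time of 48 h; on this read-out higher numbers stand for lower toxicity in this test and lower numbers for higher toxicity in this test; compound 2 `COc1cc(-c2nn(-c3cccc(NC(=O)Nc4cccc(C(F)(F)F)c4)c3)cc2-c2ccncc2)ccc1Cl` gives 25500 nM, and compound 3 `COc1cc(-c2nn(-c3cccc(NC(=O)Nc4ccc(Cl)c(C(F)(F)F)c4)c3)cc2-c2ccncc2)ccc1Cl` gives 13300 nM. Compound 3 sits within the scatter of both neighbours: a 1.0-fold higher number from compound 1 to compound 3 (0.01 log units; within the scatter) and a 1.9-fold lower number from compound 2 to compound 3 (0.28 log units; within the scatter). Compound 4 `COc1cc(-c2nn(-c3cccc(NC(=O)c4ccccc4)c3)cc2-c2ccncc2)ccc1Cl` carries a different change, (phenyl in place of (4-chloro-3-(trifluoromethyl)phenyl)amino on a carbonyl carbon). Among the measured compounds shown here, no measured step alters this part of the molecule; the three steps seen, including a 2.0-fold higher number from compound 1 to compound 2 (0.30 log units; within the scatter), all stayed within the scatter. The estimated step of a 1.5-fold higher number from compound 3 to compound 4 (0.18 log units; within the scatter) is therefore small. Compound 4 is expected to give about 20000 nM, within a range of 8000 nM to 60000 nM.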

Compound 4, concentration lethal to 50% of the cells: > 100000 nM
Compound 4 ended at the assay's limit (the forecaster's own chance of this, stated with the estimate: 10%); middle value at least 5.0-fold (0.69 log units) away from the limit.
By their numbers in this assay, from the lowest: compounds 1, 3 and 2 (each within the scatter of the next). At a limit, above all of these: compound 4.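

Where changes to the ring on the urea had stayed within the scatter, replacing the whole arylamino group with phenyl on this carbonyl carbon gives an at least 7.5-fold higher number from compound 3 to compound 4 (0.87 log units; beyond the scatter) and an at least 3.9-fold higher number from compound 2 to compound 4 (0.59 log units; beyond the scatter) and an at least 7.7-fold higher number from compound 1 to compound 4 (0.88 log units; beyond the scatter) in this assay. Toxicity in this test therefore falls clearly with this change. Compound 4 stands at a limit of the assay, not at a number: the limit of > 100000 nM in this assay, at which 1 of the 4 values shown sits.

The change removes the urea nitrogen and the ring substituents together, so their shares cannot be separated. An unsubstituted phenylamino group, or a phenyl carrying chloro and trifluoromethyl directly on the carbonyl carbon, would tell them apart.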